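Sulfonyl aryl swap on the shared core

The source may report more compounds than this note shows. Statements on the series, on what has been measured and on what is new or still open speak of the compounds shown alone.

Compound 3 `O=S(=O)(c1cc(F)cc(F)c1)c1cnc2c(F)cccc2c1-c1cccc(Cl)c1` stands lowest of the three numbers in an ADME assay on microsomes from liver (Homo sapiens) for metabolic stability, tested at 2.5 uM (a lower number here means slower removal, a higher number faster removal of the compound), where compound 3 gives 0.64 mL/min. Compound 2 `Cc1ccc(S(=O)(=O)c2cnc3c(F)cccc3c2-c2ccc(Cl)cc2)cc1F` gives 2.2 mL/min and compound 1 `Cc1ccc(S(=O)(=O)c2cnc3c(F)cccc3c2-c2cccc(F)c2)cc1F` gives 3.92 mL/min; both gaps to compound 3 are beyond the scatter. Among the measured compounds shown here, the one measured step, a 1.8-fold lower number from compound 1 to compound 2 (0.25 log units; within the scatter), changes the aryl on the core rather than the group on the sulfonyl sulfur and lies within the scatter, so it does not bear directly on the present change. Compound 4 `Cc1ccc(S(=O)(=O)c2cnc3c(F)cccc3c2-c2cccc(Cl)c2)cc1F` differs from compound 3 in one place: 3-fluoro-4-methylphenyl in place of 3,5-difluorophenyl on a sulfonyl sulfur. For the measured compounds named here, no measured pair isolates this change, so the expectation rests on what the values show: compounds 1 and 2 both carry the entering 3-fluoro-4-methylphenyl and both sit higher than compound 3, though each also differs from compound 3 in the aryl on the core. A step upward from compound 3 of roughly the size of those gaps is therefore expected, as a 3.9-fold higher number from compound 3 to compound 4 (0.59 log units; beyond the scatter). Compound 4 is estimated at 2.5 mL/min in this assay, with a range of 1 mL/min to 6 mL/min.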

Compound 4, intrinsic clearance in a liver preparation (reported as CLH), per the amount of preparation that the assay uses: 3.18 mL/min
Beside the measured number, compound 4's estimate is 1.3-fold (0.10 log units) below it; low and high end bracket the measured number.
By their numbers in this assay, from the lowest: compound 3; then compounds 2, 4 and 1 (each within the scatter of the next).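

Among the compounds shown here, with 3-chlorophenyl held constant on the shared core, a 5.0-fold higher number from compound 3 to compound 4 (0.70 log units; beyond the scatter) in this assay is the first read of the group on the sulfonyl sulfur alone, and 3-fluoro-4-methylphenyl in place of 3,5-difluorophenyl moves the number beyond the scatter. With 3-fluoro-4-methylphenyl on the sulfonyl sulfur, the aryl changes on the aromatic carbon give a 1.4-fold higher number from compound 2 to compound 4 (0.16 log units; within the scatter) and a 1.2-fold lower number from compound 1 to compound 4 (0.09 log units; within the scatter), both within the scatter, so this position shows no resolved effect across these three aryl groups. Nothing available gives a reason for the step at the sulfonyl sulfur.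

On these data alone, whether 3,5-difluorophenyl gives a similar step alongside 3-fluorophenyl or 4-chlorophenyl on the core remains open. Also open, as far as these compounds go, is how the number responds to an amine or a longer alkyl chain on the sulfonyl sulfur.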